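Working notes on the aryl substituent step to compound 4

The source may report more compounds than this note shows. Statements on the series, on what has been measured and on what is new or still open speak of the compounds shown alone.

Measured so far in a functional assay on DU-145 cells (Homo sapiens) for antiproliferative activity, read by MTT assay, with a stated time of 48 h; on this read-out higher numbers stand for weaker inhibition and lower numbers for stronger inhibition:
Compound 1 `C#CCOC(=O)/C(C)=C/CC/C(C)=C/CC/C(C)=C/CC[C@@H]1[C@@]2(C)CCC(=O)C(C)(C)[C@H]2CC[C@@]1(C)O`: compound 1 gives 46100 nM.
Compound 2 `C/C(=C\CC/C(C)=C/CC[C@@H]1[C@@]2(C)CCC(=O)C(C)(C)[C@H]2CC[C@@]1(C)O)CC/C=C(\C)C(=O)OCc1cn(-c2ccc([N+](=O)[O-])cc2)nn1`: compound 2 gives only a limit, > 150000 nM.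
Compound 3 `C/C(=C\CC/C(C)=C/CC[C@@H]1[C@@]2(C)CCC(=O)C(C)(C)[C@H]2CC[C@@]1(C)O)CC/C=C(\C)C(=O)OCc1cn(-c2cccc(Cl)c2)nn1`: compound 3 gives 103000 nM.

Compound 3 holds the highest of the two numbers; the nearest is compound 1, with a 2.2-fold higher number from compound 1 to compound 3 (0.35 log units; beyond the scatter). The other value is a limit of the assay, (the limit of > 150000 nM in this assay, at which 1 of the 3 values shown sits), so the step of an at least 1.4-fold lower number from compound 2 to compound 3 (0.16 log units; that floor lies within the scatter) has only a floor, and that floor lies within the scatter.

Compound 4 `C/C(=C\CC/C(C)=C/CC[C@@H]1[C@@]2(C)CCC(=O)C(C)(C)[C@H]2CC[C@@]1(C)O)CC/C=C(\C)C(=O)OCc1cn(-c2cccc(C(F)(F)F)c2)nn1` differs from compound 3 by trifluoromethyl in place of chloro on an aromatic carbon. Among the compounds with values here, of the measured steps, only the one from compound 2 to compound 3 touches the same place, the group on the aromatic nitrogen, and it gave no change resolvable beyond the scatter. The step from compound 1 to compound 3 alters a different part of the molecule and is modest. No step beyond the scatter is therefore expected here, in either direction.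

Compound 4 is expected to give 110000 nM in this assay, estimated between 50000 nM and 200000 nM. The step of a 1.1-fold higher number from compound 3 to compound 4 (0.03 log units; within the scatter) is expected to stay within the scatter.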

Compound 4, half-maximal inhibitory concentration: > 150000 nM
Compound 4: only a limit was reported; the forecaster's own chance of this, stated with the estimate: 30%; middle value at least 1.3-fold (0.13 log units) from the limit.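

Trifluoromethyl in place of chloro on this aromatic carbon, meta to a large group, gives an at least 1.4-fold higher number from compound 3 to compound 4 (0.16 log units; that floor lies within the scatter), so the change is bounded on one side only and its true size stays unread. The step between compound 2 and compound 4 cannot be read, as both report only a limit. Of the three aryl groups on the triazole nitrogen, only 3-chlorophenyl in compound 3 gives a number rather than a limit, and the limit now recurs among the values: the limit of > 150000 nM in this assay, at which 2 of the 4 values shown sit.

The compounds shown leave open whether an amine, a carboxylic acid or a methoxy group on this aromatic carbon, or an unsubstituted phenyl, would give a number rather than a limit. As far as these compounds go, whether the true values of compound 2 and compound 4 differ at all also remains open.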